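Urea-to-benzamide change in a pyrazole inhibitor series

The compounds below may be only part of what the source reports. "The series", "measured", "known", "first", "only" and "open" are said of these compounds alone.

Measured compounds:
Compound 1, `COc1cc(-c2nn(-c3cccc(NC(=O)Nc4ccc(Cl)c(Cl)c4)c3)cc2-c2ccncc2)ccc1Cl`, gives 2420 nM in a functional assay on Malme-3M cells (Homo sapiens) for inhibition, read by sulforhodamine B assay, with a stated time of 48 h; a lower number here means a stronger inhibitor of growth, a higher number a weaker inhibitor of growth.
Compound 2, `COc1cc(-c2nn(-c3cccc(NC(=O)Nc4ccc(Cl)c(C(F)(F)F)c4)c3)cc2-c2ccncc2)ccc1Cl`, gives 2350 nM in this assay.

Within the data shown here, compound 2 stands at one of two numbers that lie within the scatter of each other; the only measured step, a 1.0-fold lower number from compound 1 to compound 2 (0.01 log units; within the scatter), shows no change beyond the scatter, so the two compounds cannot be ranked against each other.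

Compound 3, `COc1cc(-c2nn(-c3cccc(NC(=O)c4ccccc4)c3)cc2-c2ccncc2)ccc1Cl`, differs from compound 2 by phenyl in place of (4-chloro-3-(trifluoromethyl)phenyl)amino on a carbonyl carbon. Among the measured compounds shown here, no measured step touches this part of the molecule: the one recorded step alters a substituent on the very ring that is removed here, and it says nothing about the size of the present change. The expectation for compound 3 therefore rests only on the two measured values, which sit at about the same level, and carries wide uncertainty in both directions. In this assay the expected step is a 3.0-fold higher number from compound 2 to compound 3 (0.47 log units; beyond the scatter). The estimated value for compound 3 is 7000 nM, with a range from 2000 nM to 30000 nM.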

Compound 3, concentration for total growth inhibition: > 100000 nM
Compound 3 was reported as a limit; the forecaster's own chance of this, stated with the estimate: 15%; middle value at least 14-fold (1.15 log units) from the limit.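

Compound 3 is reported only as a limit in this assay, not as a number: the limit of > 100000 nM in this assay, at which 1 of the 3 values shown sits.

On the carbonyl carbon, phenyl in place of (4-chloro-3-(trifluoromethyl)phenyl)amino gives an at least 42-fold higher number from compound 2 to compound 3 (1.62 log units; beyond the scatter), and phenyl in place of (3,4-dichlorophenyl)amino gives an at least 41-fold higher number from compound 1 to compound 3 (1.61 log units; beyond the scatter). The earlier pair showed only that trifluoromethyl in place of chloro on the aromatic ring leaves the number unchanged, with a 1.0-fold lower number from compound 1 to compound 2 (0.01 log units; within the scatter); the present steps show that this place is far less tolerant, and that growth inhibition in this assay is lost when the whole substituted phenylamino group gives way to phenyl.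

This change removes the nitrogen with its hydrogen-bond donor and the ring substituents together, and the compounds shown cannot separate the two contributions. The deciding comparisons would be an unsubstituted phenylamino group on the carbonyl carbon, which keeps the nitrogen without the chloro and trifluoromethyl groups, and a 4-chloro-3-(trifluoromethyl)phenyl group placed directly on that carbon, which keeps those groups without the nitrogen.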